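The source may hold more compounds than are shown below. What is called first, only, known or untested is meant among the compounds shown, and "the series" means these compounds.

In a functional assay on MCF7 cells (Homo sapiens) for inhibition, read by MTT assay, with a stated time of 72 h (a lower number here means a stronger inhibitor, a higher number a weaker inhibitor), compound 2 `C=C(Br)C(=O)Nc1cccc(/C=C/C(=O)Nc2ccc(OC)cc2)c1` gives 2500 nM and compound 1 `C=C(Br)C(=O)Nc1cccc(/C=C/C(=O)Nc2cccc(F)c2)c1` gives 3300 nM, so the two stand within the scatter of each other. Compound 3 `C=C(Br)C(=O)Nc1cccc(/C=C/C(=O)Nc2ccc(OC)c(OC)c2)c1` differs from compound 2 by one change: methoxy in place of hydrogen on an aromatic carbon, ortho to a methoxy group. Among the compounds with values here, the only measured step, a 1.3-fold lower number from compound 1 to compound 2 (0.12 log units; within the scatter), swaps the group on the amide-type nitrogen that also carries this change. Its size gives no reason to expect a shift beyond the scatter in this assay. The expected change is a 1.1-fold lower number from compound 2 to compound 3 (0.04 log units; within the scatter). For compound 3 the estimate is 2300 nM, with an expected range of 1000 nM to 5500 nM.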

Compound 3, half-maximal inhibitory concentration: 2800 nM
Estimate against measurement, compound 3: 1.2-fold (0.09 log units) below; the range from low to high includes it.
By their numbers in this assay, from the lowest: compounds 2, 3 and 1 (each within the scatter of the next).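

Adding methoxy in place of hydrogen, ortho to a methoxy group, gives a 1.1-fold higher number from compound 2 to compound 3 (0.05 log units; within the scatter) in this assay, so this position takes the added group with no shift beyond the scatter. The earlier step swapped the whole group on the amide-type nitrogen, whereas this one isolates a single addition on that aromatic ring. No supporting data bear on why the number stays flat here.

On these data alone, whether an amine or a carboxylic acid at this position would move the number beyond the scatter remains open.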